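Dropping One Trifluoromethyl from a Urea Pyrazole

This account rests on a few compounds, and the source may have more. Where it says the series, first, only, none or still open, it means among the compounds named here.

Compound 1: `O=C(Nc1cccc(-n2cc(-c3ccncc3)c(-c3cc(O)cc(Cl)c3)n2)c1)Nc1ccc(Cl)c(C(F)(F)F)c1`, 96%
Compound 2: `COc1cc(Cl)cc(-c2nn(-c3cccc(NC(=O)Nc4cc(C(F)(F)F)cc(C(F)(F)F)c4)c3)cc2-c2ccncc2)c1`, 27%

In a functional assay on DU-145 cells (Homo sapiens) for inhibition, read by sulforhodamine B assay, with a stated time of 48 h, tested at 1 uM (a lower number here means a stronger effect, a higher number a weaker effect of the compound at the concentration tested), compound 2 gives 27%, the lower of the two numbers and therefore the stronger effect; compound 1, the nearest neighbour, gives 96%, a gap well beyond the usual scatter. The two compounds differ in more than one place, so no single change can be credited with that gap.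

Compound 3 is `COc1cc(Cl)cc(-c2nn(-c3cccc(NC(=O)Nc4cccc(C(F)(F)F)c4)c3)cc2-c2ccncc2)c1`. It differs from compound 2 in one place: hydrogen in place of trifluoromethyl on an aromatic carbon.

For the measured compounds named here, no step between the measured compounds isolates this change, so the expectation rests on the general picture. Compound 3 is expected to lose some of the effect of compound 2, with a step of a number 23 percentage points higher from compound 2 to compound 3 (beyond the scatter) in this assay, upward and probably beyond the scatter, but not back to the level of compound 1. The estimate for compound 3 is 50%, within a range of 25% to 80%.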

Compound 3, a percentage reported as activity, at one concentration (the size of the read-out at that concentration, not a potency): 73%
Estimate against measurement, compound 3: 23 percentage points below; low and high end bracket the measured number.
By their numbers in this assay, from the lowest: compound 2; then compound 3; then compound 1.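

For the compounds shown here, the change gives the first clean reading at this position: in this assay, hydrogen in place of trifluoromethyl on this aromatic carbon produces a large step (a number 46 percentage points higher from compound 2 to compound 3 (beyond the scatter)), beyond the scatter. Removing this one trifluoromethyl is thus enough on its own to weaken the effect substantially at the concentration tested, which compound 1 and compound 2 could not show, as they differ in more than one place. Nothing measured here explains why the loss is so large.

The compounds shown leave open whether a nitrile, a methyl or an amine on this carbon would keep the effect seen with compound 2. They also leave open whether the same change would cost as much with the rest of the molecule altered, for instance with a hydroxyl in place of the methoxy.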